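The compounds below may be only part of what the source reports. "The series", "measured", "known", "first", "only" and "open" are said of these compounds alone.

Measured compounds, antiproliferative read-out:
compound 1, `NC(=O)c1c(NC(=O)c2ccccc2Cl)sc2c1CCN(Cc1ccccc1F)C2`, 21800 nM
compound 2, `NC(=O)c1c(NC(=O)c2ccccc2Cl)sc2c1CCN(Cc1cc(Cl)cc(Cl)c1)C2`, 15800 nM
compound 3, `NC(=O)c1c(NC(=O)c2ccc(C(F)(F)F)cc2)sc2c1CCN(Cc1ccccc1F)C2`, > 50000 nM

The three compounds share one core and differ in two places. In a functional assay on HL-60 cells (Homo sapiens) for antiproliferative activity, with a stated time of 24 h (on this read-out lower numbers stand for stronger inhibition and higher numbers for weaker inhibition), compound 1 gives 21800 nM and compound 2 gives 15800 nM; the change between them, a 1.4-fold lower number from compound 1 to compound 2 (0.14 log units; within the scatter), stays inside the usual scatter. Compound 3 carries 4-(trifluoromethyl)phenyl on the carbonyl carbon, and the step of an at least 2.2-fold higher number from compound 1 to compound 3 (0.36 log units; beyond the scatter) is only a lower bound, since compound 3 reaches the limit of the assay. For compound 3 the assay reports only that limit, > 50000 nM, which is the limit of > 50000 nM in this assay, at which 1 of the 3 values shown sits.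

Compound 4, `NC(=O)c1c(NC(=O)c2ccc(C(F)(F)F)cc2)sc2c1CCN(C(=S)Nc1ccccc1Cl)C2`, keeps the 4-(trifluoromethyl)phenyl amide of compound 3 and changes the other position: a group of 10 heavy atoms (7 carbon, 1 nitrogen, 1 sulfur, 1 chlorine; one six-membered aromatic ring of carbon only) in place of a group of 8 heavy atoms (7 carbon, 1 fluorine; one six-membered aromatic ring of carbon only), on an amine nitrogen in a ring
The 2-fluorobenzyl leaves and a group with no common name enters on the amine nitrogen in the ring. Among the compounds with values here, no measured step covers this kind of exchange; the only step at the same position, a 1.4-fold lower number from compound 1 to compound 2 (0.14 log units; within the scatter), swapped one benzyl for another and moved nothing beyond the scatter. Because compound 3 already sits at > 50000 nM, compound 4 is expected to remain near or beyond that limit, with a step that the limit leaves unreadable from compound 3 to compound 4 that is not expected to exceed the scatter. Compound 4 is therefore estimated at 60000 nM in this assay, between 20000 nM and 180000 nM.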

Compound 4, half-maximal inhibitory concentration: 36100 nM
Compound 4: the middle estimate sits 1.7-fold (0.22 log units) above what was measured; the measured number falls inside the stated range.
By their numbers in this assay, from the lowest: compounds 2, 1 and 4 (each within the scatter of the next, the first and the last beyond it). At a limit, above all of these: compound 3.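

In this assay, replacing the 2-fluorobenzyl on the amine nitrogen in a ring with a group of 10 heavy atoms, which brings 1 hydrogen-bond donor, 1 hydrogen-bond acceptor and 1 double bond outside aromatic rings, gives an at least 1.3-fold lower number from compound 3 to compound 4 (0.14 log units; that floor lies within the scatter). The value of compound 3 is a limit and not a number: the limit of > 50000 nM in this assay, at which 1 of the 4 values shown sits.

Within the data shown here, what the earlier compounds did not show is that, with the 4-(trifluoromethyl)phenyl kept on the carbonyl carbon, a group other than a benzyl at this position gives a value that can be read as a number, with compound 4 at 36100 nM.

The compounds shown leave open which part of the entering group matters, for instance whether a carbonyl oxygen in place of its sulfur, or a plain alkyl chain in place of its chlorine-bearing aromatic ring, would give a similar number. They also leave open how the same group would read with the 2-chlorophenyl on the carbonyl carbon, the combination in which compound 1 and compound 2 give numbers rather than a limit.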